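The source may hold more compounds than are shown below. What is called first, only, known or untested is meant among the compounds shown, and "the series" means these compounds.

Of the compounds shown here, three sharing one core have been measured in a functional assay on T47D cells (Homo sapiens) for cytotoxicity, read by MTT assay, with a stated time of 24 h; a higher number here means a weaker inhibitor, a lower number a stronger inhibitor. Compound 1 `COc1ccc(/C=C\C(=O)O)c(OCc2cn(-c3cccc(C#N)c3)nn2)c1CC=C(C)C` gives 19200 nM, compound 2 `COc1ccc(/C=C\C(=O)O)c(OCc2cn(-c3ccc(CO)cc3)nn2)c1CC=C(C)C` gives 40000 nM, and compound 3 `COc1ccc(/C=C\C(=O)O)c(OCc2cn(-c3ccc(C#N)cc3)nn2)c1CC=C(C)C` gives 10200 nM. Compound 3 thus has the lowest number of the three: its separation from compound 1 is a 1.9-fold lower number from compound 1 to compound 3 (0.27 log units; within the scatter), and its separation from compound 2 is a 3.9-fold lower number from compound 2 to compound 3 (0.59 log units; beyond the scatter). Between compound 1 and compound 2 the step is a 2.1-fold higher number from compound 1 to compound 2 (0.32 log units; beyond the scatter).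

Compound 4 `COc1ccc(/C=C\C(=O)O)c(OCc2cn(-c3nc4ccccc4s3)nn2)c1CC=C(C)C` differs from compound 3 in one place: 1,3-benzothiazol-2-yl in place of 4-cyanophenyl on an aromatic nitrogen. Among the measured compounds shown here, no measured step exchanges the whole aryl ring for a fused bicyclic heteroaryl; the steps on record only move the nitrile around the ring or swap nitrile for hydroxymethyl, and even those changes stay modest. The nearest guidance is the pair compound 3 and compound 1, whose difference in this assay sits within the scatter, and the pair compound 2 and compound 3, whose difference is modest. Compound 4 is therefore expected to land close to compound 3, with an expected step of a 1.5-fold higher number from compound 3 to compound 4 (0.17 log units; within the scatter) and with a wide margin of uncertainty. The estimate for compound 4 in this assay is 15000 nM, within a range from 5000 nM to 45000 nM.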

Compound 4, half-maximal inhibitory concentration: 17200 nM
For compound 4 the middle estimate is 1.1-fold (0.06 log units) below the measured one; low and high end bracket the measured number.
By their numbers in this assay, from the lowest: compounds 3, 4 and 1 (each within the scatter of the next); then compound 2.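

In this assay, among the compounds shown here, the earlier compounds only moved the nitrile around the ring on the aromatic nitrogen or replaced it with hydroxymethyl, whereas compound 4 shows that this position also accepts the exchange of the whole 4-cyanophenyl for 1,3-benzothiazol-2-yl, with no nitrile and with a second ring and a sulfur atom, and the result stays within the scatter (first a 1.7-fold higher number from compound 3 to compound 4 (0.23 log units; within the scatter), and then a 1.1-fold lower number from compound 1 to compound 4 (0.05 log units; within the scatter)). Only the hydroxymethyl compound stands apart from this new group (here a 2.3-fold lower number from compound 2 to compound 4 (0.37 log units; beyond the scatter)), so among these four compounds, compound 2 is the only one separated from the others, and a nitrile is not required to stay level with compound 3 and compound 1. Nothing available explains why the two different groups give numbers so close together.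

The compounds shown leave open whether a plain phenyl, or a phenyl carrying an amine, would stay with compound 3 or fall towards compound 2. They also leave open whether a 1,3-benzothiazol-2-yl bearing a further group, such as methoxy, would shift the number beyond the scatter.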